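Replacing the Chlorophenoxypropyl Group with a Carbamate

The source may report more compounds than this note shows. Statements on the series, on what has been measured and on what is new or still open speak of the compounds shown alone.

Compound 1, `CC(C)=CCC1Cc2c(O)cc(=O)n(CCCO)c2CC1(C)C`: 25.6%
Compound 2, `CC(C)=CCC/C(C)=C/COc1cc(=O)n(CCCO)c2c1CC(CC=C(C)C)C(C)(C)C2`: 10.6%
Compound 3, `CC(C)=CCC1Cc2c(OCCCOc3ccc(Cl)cc3)cc(=O)n(CCCO)c2CC1(C)C`: 22.7%

In a functional assay on PANC-1 cells (Homo sapiens) for inhibition, read by MTT assay, with a stated time of 24 h, tested at 10 uM (on this read-out lower numbers stand for less inhibition and higher numbers for more inhibition at the one concentration tested (going by the name of the read-out)), compound 3 gives 22.7%, the second highest of the three numbers. Its nearest neighbour is compound 1, since a number 2.9 percentage points lower from compound 1 to compound 3 (within the scatter); its furthest is compound 2, since a number 12.1 percentage points higher from compound 2 to compound 3 (beyond the scatter). Compound 4, `COc1ccc(NC(=O)Oc2cc(=O)n(CCCO)c3c2CC(CC=C(C)C)C(C)(C)C3)cc1`, differs from compound 3 by (4-methoxyphenyl)carbamoyl in place of 3-(4-chlorophenoxy)propyl on an oxygen on an aromatic ring. Both measured steps that touch this oxygen bear on the change, yet neither involves a carbamoyl group, so the direction of the new step is not fixed by them. Compound 4 is therefore expected to stay close to compound 3, with an estimated 20% (range 8% to 35%), which means an expected a number 2.7 percentage points lower from compound 3 to compound 4 (within the scatter).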

Compound 4, a percentage reported as inhibition, at one concentration (the size of the read-out at that concentration, not a potency): 3.7%
Estimate against measurement, compound 4: 16.3 percentage points above; measured number outside the range, below it.
By their numbers in this assay, from the lowest: compounds 4 and 2 (each within the scatter of the next); then compounds 3 and 1 (each within the scatter of the next).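

At this oxygen on an aromatic ring, (4-methoxyphenyl)carbamoyl brings the number down in this assay against both 3-(4-chlorophenoxy)propyl and hydrogen, with a number 19 percentage points lower from compound 3 to compound 4 (beyond the scatter) and a number 21.9 percentage points lower from compound 1 to compound 4 (beyond the scatter). Against the 3,7-dimethylocta-2,6-dien-1-yl group, however, there is a number 6.9 percentage points lower from compound 2 to compound 4 (within the scatter), so the four compounds fall into a higher pair, compound 1 and compound 3, and a lower pair, compound 2 and compound 4. No evidence is available on the cause of these differences. As far as these compounds go, whether the drop comes from the carbamoyl link or from the 4-methoxyphenyl ring stays open. An ethylcarbamoyl or an acetyl group on this oxygen would help separate the two.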